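A few compounds are considered here, and "the series" means these few. Any claim that something is new, unique, unknown or untested is made for them only; others in the source may bear on it.

In an ADME assay on HEK293 cells (Homo sapiens) for cytotoxicity, read by resazurin assay, with a stated time of 48 h (on this read-out higher numbers stand for an effect only at larger amounts of compound and lower numbers for an effect already at smaller amounts), compound 1 (`CNC(=O)Nc1ccc2nc(-c3ccco3)c(-c3ccco3)nc2c1`) gives > 100000 nM as a limit of the assay and not a number. Going by the values given here, compound 2 (`COC(=O)c1ccc(-c2ccc(/C=C3/SC(=S)NC3=O)o2)cc1`), of a different structure, gives 44000 nM as the only exact value so far. Compound 3 (`O=C(Nc1ccc2nc(-c3ccco3)c(-c3ccco3)nc2c1)N1CCCC1`) keeps the core of compound 1 and carries pyrrolidin-1-yl in place of methylamino on a carbonyl carbon. Among the compounds with values here, no measured step bears on this change, so in this assay no shift beyond the scatter is expected, and a number no higher from compound 1 to compound 3 (the limit leaves the size open) is the estimated step. For compound 3 the estimated value is 100000 nM with an expected range from 40000 nM to 200000 nM on this read-out.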

Compound 3, half-maximal effective concentration: > 100000 nM
Compound 3 gave a limit, no number; the forecaster's own chance of this, stated with the estimate: 60%; the middle value sits exactly at the limit.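

No step can be read from compound 1 to compound 3, because both give only a limit and no number: the limit of > 100000 nM in this assay, at which 2 of the 3 values shown sit. Going by these compounds, whether pyrrolidin-1-yl in place of methylamino on a carbonyl carbon shifts the value in this assay at all remains open.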